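This account rests on a few compounds, and the source may have more. Where it says the series, first, only, none or still open, it means among the compounds named here.

Measured so far in a functional assay on HEK293 cells for positive allosteric modulation of metabotropic glutamate receptor 5 (Rattus norvegicus), read by fluorescence and calcium flux; a higher number here means a larger maximal response, a lower number a smaller maximal response:

compound 1, `C[C@@H](NC(=O)c1ccc(C#CC2CCCC2)cn1)C(C)(C)O`, gives 63.7%
compound 2, `C[C@@H](NC(=O)c1ccc(C#Cc2cccc(F)c2)cc1)C(C)(C)O`, gives 53.9%
compound 3, `CC(C)(C)CNC(=O)c1ccc(C#Cc2cccc(F)c2)cn1`, gives 63.9%

Compound 3 sits at the top of the three numbers as they read, but the gap to compound 1 is very small and the gap to compound 2 is larger, and both gaps fall within the usual scatter of repeated measurements. No order among the three can therefore be claimed; on these numbers the three compounds are not separated in this assay.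

The next compound in the series is compound 4, `CC1(CCNC(=O)c2ccc(C#Cc3cccc(F)c3)cn2)COC1`, which differs from compound 3 in one place: (3-methyloxetan-3-yl)methyl in place of tert-butyl on a saturated chain carbon bound to an amide-type nitrogen. The rest of the molecule, including the shared core of compound 3 and the fluorophenylethynyl part, is kept.

Going by the values given here, no pair of measured compounds differs in one place, so no measured step can be carried over to this change. Among the compounds with values here, the three values at hand show no movement beyond the scatter between the neopentyl amide of compound 3 and the differently substituted amides of compound 1 and compound 2, which is the only guide available. Expectation for compound 4 in this assay is therefore a step from compound 3 to compound 4 of about a number 2.9 percentage points lower from compound 3 to compound 4 (within the scatter), that is, none beyond the scatter in either direction. The estimated value for compound 4 is 61%, with a range from 45% to 77%.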

Compound 4, largest response reached (reported as efficacy), in percent of the reference or control that the assay uses: 65.7%
Compound 4: the middle estimate sits 4.7 percentage points below what was measured; the measured number falls inside the stated range.
By their numbers in this assay, from the lowest: compounds 2, 1, 3 and 4 (each within the scatter of the next, the first and the last beyond it).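

In this assay, going by these compounds alone, (3-methyloxetan-3-yl)methyl in place of tert-butyl on a saturated chain carbon bound to an amide-type nitrogen gives a number 1.8 percentage points higher from compound 3 to compound 4 (within the scatter), the only step so far that changes a single place. This position therefore accepts a larger group, with a four-membered ring holding one oxygen and a hydrogen-bond acceptor that tert-butyl lacks, and the maximal response does not move beyond the scatter. Nothing available bears on why the response holds across this change.

Still open, from the compounds shown here alone, is whether the ring oxygen matters at all, which a comparison with the all-carbon (1-methylcyclobutyl)methyl group at the same place could address, and how this position responds to a piperidine, a carboxylic acid or a longer alkyl chain. Also open, going by these compounds, is whether the same exchange behaves alike on the amides carrying the cyclopentylethynyl part of compound 1 or the core of compound 2, each of which differs from compound 3 in more than one place.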